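Sulfonamide Amines on HT-29 Cells: A Benzyl Change

The source may report more compounds than this note shows. Statements on the series, on what has been measured and on what is new or still open speak of the compounds shown alone.

The series shares a bis(trifluoromethyl)phenyl sulfonamide joined through a short chain to a benzylic amine, and all values come from a functional assay on HT-29 cells (Homo sapiens) for inhibition, read by MTT assay, with a stated time of 72 h; a lower number here means a stronger inhibitor of growth, a higher number a weaker inhibitor of growth. Compound 1 `O=S(=O)(NCCNCc1ccc(-c2ccccc2)cc1)c1cc(C(F)(F)F)cc(C(F)(F)F)c1` gives 2700 nM in this assay. For the measured compounds named here, compound 3 `CC(C)(C)c1ccc(CNCCNS(=O)(=O)c2cc(C(F)(F)F)cc(C(F)(F)F)c2)cc1` gives 14000 nM, and the step of a 5.2-fold higher number from compound 1 to compound 3 (0.71 log units; beyond the scatter) is the only single change measured so far. Compound 2 `CN(CCCNS(=O)(=O)c1cc(C(F)(F)F)cc(C(F)(F)F)c1)Cc1ccccc1` gives only a limit, > 50000 nM, in this assay. Going by the values given here, its position is set by the limit of > 50000 nM in this assay, at which 1 of the 3 values shown sits, so no number and no step can be computed for it.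

Compound 4 `COc1ccccc1CNCCCNS(=O)(=O)c1cc(C(F)(F)F)cc(C(F)(F)F)c1` differs from compound 2 by (2-methoxybenzyl)amino in place of benzyl(methyl)amino on a saturated chain carbon, three bonds along the chain from a sulfonamide nitrogen. Among the compounds with values here, the one measured step, from compound 1 to compound 3, concerns a group on the aromatic ring and a different chain length, and does not bear on the loss of a methyl on the amine nitrogen or the entry of a methoxy group; no measured pair shows either change. With compound 2 sitting at a limit, the direction of the step of an at least 1.6-fold lower number from compound 2 to compound 4 (0.22 log units; that floor lies within the scatter) can only be expected loosely, and it is expected to be small or within scatter. Compound 4 is therefore estimated at 30000 nM, with a range from 8000 nM to 100000 nM.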

Compound 4, concentration for 50% growth inhibition: 12000 nM
The estimate for compound 4 lay 2.5-fold (0.40 log units) above the measured number; the range from low to high includes it.
By their numbers in this assay, from the lowest: compound 1; then compounds 4 and 3 (each within the scatter of the next). At a limit, above all of these: compound 2.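

In this assay, for the compounds shown here, putting (2-methoxybenzyl)amino in place of benzyl(methyl)amino on a saturated chain carbon, three bonds along the chain from a sulfonamide nitrogen, gives an at least 4.1-fold lower number from compound 2 to compound 4 (0.61 log units; beyond the scatter) and so provides the first measured step at the amine end of the chain. The change moves a compound with no number into measurable range, showing that this position can respond to a change made at the amine while the sulfonamide side stays the same. The size of the step remains only a floor, and compound 2 remains a limit and not a number: the limit of > 50000 nM in this assay, at which 1 of the 4 values shown sits.

The step also combines two changes, the loss of the methyl on the amine nitrogen and the entry of a methoxy group, and with them the rise from 0 to 1 hydrogen-bond donors and from 1 to 2 hydrogen-bond acceptors, so the compounds shown cannot say which part carries it. A plain benzylamino group on the same chain would separate the two, and an ethoxy group in place of the methoxy would show whether this group can be enlarged.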